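Lengthening the Amide Chain by One Carbon

The source may report more compounds than this note shows. Statements on the series, on what has been measured and on what is new or still open speak of the compounds shown alone.

Among the compounds with values here, compound 2 `C/C=C\C(=O)Nc1cc(Nc2nccc(-c3cn(C)c4ccccc34)n2)c(OC)cc1N(C)CCN(C)C` shows the lowest of the two numbers so far in a functional assay on A549 cells (Homo sapiens) for antiproliferative activity, read by MTT assay, with a stated time of 72 h (on this read-out lower numbers stand for stronger inhibition and higher numbers for weaker inhibition), where compound 2 gives 660 nM, while compound 1 `C=C(F)C(=O)Nc1cc(Nc2nccc(-c3cn(C)c4ccccc34)n2)c(OC)cc1N(C)CCN(C)C` gives 2460 nM. Within the data shown here, the only measured step is a 3.7-fold lower number from compound 1 to compound 2 (0.57 log units; beyond the scatter), which exchanges 1-fluoroethenyl for prop-1-en-1-yl on the carbonyl carbon. Compound 3 `CC/C=C\C(=O)Nc1cc(Nc2nccc(-c3cn(C)c4ccccc34)n2)c(OC)cc1N(C)CCN(C)C` is not yet measured; it differs from compound 2 by methyl in place of hydrogen on a saturated chain carbon bound to a double-bonded chain carbon, so that prop-1-en-1-yl on the carbonyl carbon becomes but-1-en-1-yl. That measured step touches the same group but swaps one group for another rather than adding a single carbon to a chain, so it gives only loose guidance; because it amounted to a 3.7-fold lower number from compound 1 to compound 2 (0.57 log units; beyond the scatter), changes at this position can shift the number, yet the present change is smaller. Compound 3 is therefore expected to stay close to compound 2, with a step of a 1.4-fold higher number from compound 2 to compound 3 (0.13 log units; within the scatter). The estimate for compound 3 is 900 nM, in a range from 300 nM to 2700 nM.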

Compound 3, half-maximal inhibitory concentration: 1530 nM
Estimate against measurement, compound 3: 1.7-fold (0.23 log units) below; low and high end bracket the measured number.
By their numbers in this assay, from the lowest: compound 2; then compounds 3 and 1 (each within the scatter of the next).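

In this assay, methyl in place of hydrogen, which turns prop-1-en-1-yl into but-1-en-1-yl, gives a 2.3-fold higher number from compound 2 to compound 3 (0.37 log units; beyond the scatter) and so shows that this chain responds even to a change of this small size, something the earlier swap of one whole group for another could not show. The comparison with the fluorinated amide gives a 1.6-fold lower number from compound 1 to compound 3 (0.21 log units; within the scatter) and places but-1-en-1-yl and 1-fluoroethenyl within the scatter of each other, so that among these three groups only prop-1-en-1-yl stands apart. No measurement shown here speaks to what lies behind these differences.

On these data alone, whether a longer chain such as pent-1-en-1-yl would move the number further remains open. So does how a chain ending in an amine would read in this cell assay.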